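Moving the Pyridine Nitrogen on a Shared Core

The compounds below may be only part of what the source reports. "The series", "measured", "known", "first", "only" and "open" are said of these compounds alone.

Compound 1 `O=C([C@@H]1CCCN1)N1CCN(Cc2ccccn2)CC1` and compound 2 `O=C(C1CCCCN1)N1CCN(Cc2ccccn2)CC1` share a core and differ only in the ring attached to the carbonyl carbon. In an assay on membranes from striatum for binding affinity to Neuronal acetylcholine receptor; alpha4/beta2 (Rattus norvegicus) (on this read-out higher numbers stand for weaker inhibition and lower numbers for stronger inhibition), compound 1 gives only a limit of > 100000 nM. In this assay compound 2 likewise gives only a limit of > 100000 nM. Within the data shown here, the one measured step, a step that the two limits leave unreadable from compound 1 to compound 2, cannot be read because of the limit of > 100000 nM in this assay, at which 2 of the 2 values shown sit. Compound 3 `O=C(C1CCCCN1)N1CCN(Cc2cccnc2)CC1` differs from compound 2 by pyridin-3-yl in place of pyridin-2-yl on a saturated chain carbon bound to an amine nitrogen in a ring. Among the measured compounds shown here, no measured step touches this part of the molecule, so the measurements give no direction for the change, and compound 2 itself is known only as a limit. The expected step from compound 2 to compound 3 is an at least 1.6-fold lower number from compound 2 to compound 3 (0.22 log units; that floor lies within the scatter), a guess rather than a reading from the data. Compound 3 is therefore expected to show 60000 nM, within a range of 5000 nM to 300000 nM, with a fair chance that only a limit is reported again.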

Compound 3, inhibition constant: 54800 nM
Beside the measured number, compound 3's estimate is 1.1-fold (0.04 log units) above it; low and high end bracket the measured number.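

Among these compounds, compound 3 is the first compound here to give a measured number rather than a limit in this assay, so this position offers a change that can be followed on a scale. Swapping pyridin-2-yl for pyridin-3-yl on a saturated chain carbon bound to an amine nitrogen in a ring amounts to an at least 1.8-fold lower number from compound 2 to compound 3 (0.26 log units; that floor lies within the scatter). The real size of this step cannot be read, and it may be no larger than the usual scatter or may be much larger, because compound 2 is known only as a limit: the limit of > 100000 nM in this assay, at which 2 of the 3 values shown sit.

Going by these compounds, it remains open whether pyridin-4-yl or a plain phenyl ring at this place would give a lower or a higher number than pyridin-3-yl. On these data alone, it is also open whether pyridin-3-yl would have a similar effect with the pyrrolidin-2-yl group of compound 1 on the carbonyl carbon.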